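The compounds below may be only part of what the source reports. "The series", "measured", "known", "first", "only" and "open" are said of these compounds alone.

Measured so far:
- compound 1, `O=C(O)c1cnc(-c2ccccc2[N+](=O)[O-])[nH]c1=O`: > 50 mg/kg
- compound 2, `CCOC(=O)c1cnc(-c2ccccc2[N+](=O)[O-])[nH]c1=O`: "not determined" (no result reported)

Compound 1 carries the free acid on the shared core, and in a functional assay on the whole organism (strain Sprague-Dawley) for inhibition, with Rattus norvegicus as the target, with a stated time of 10 min (a higher number here means that more compound is needed for the effect, a lower number that less compound is needed), compound 1 reaches only a limit of the assay, > 50 mg/kg, which is the limit of > 50 mg/kg in this assay, at which 1 of the 2 values shown sits. Compound 2 is the ethyl ester of the same core; in this assay compound 2 has no result at all, "not determined" (no result reported). Compound 2 therefore stands nowhere on the numbers shown: no value of its own, and the one other value in the set is a limit.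

Compound 3, `CCCCOc1ccccc1-c1ncc(C(=O)OCC)c(=O)[nH]1`, is the next member: butoxy in place of nitro on an aromatic carbon. For the measured compounds named here, no step between measured compounds exists in the set, so the size and direction of the change from compound 2 to compound 3 in this assay cannot be anchored; the expectation is a step not clearly beyond the scatter, in either direction, with wide uncertainty. Compound 3 is estimated at 30 mg/kg, between 5 mg/kg and 100 mg/kg.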

Compound 3, dose for 50% inhibition: 0.5 mg/kg
Compound 3: the middle estimate sits 60-fold (1.78 log units) above what was measured, outside the stated range (below it).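

In this assay compound 3 gives 0.5 mg/kg, but no step can be read from it: compound 2 has no reported result, and compound 1 differs from compound 3 in more than one place. Going by these compounds, the effect of butoxy in place of nitro alone remains open.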